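A few compounds are considered here, and "the series" means these few. Any claim that something is new, unique, unknown or untested is made for them only; others in the source may bear on it.

Working notes on the series. Compound 1 `CC(C)(C)c1ccc(CNCCCNS(=O)(=O)c2cc(C(F)(F)F)cc(C(F)(F)F)c2)cc1` gives 2300 nM in a functional assay on MIA PaCa-2 cells (Homo sapiens) for inhibition, read by MTT assay, with a stated time of 72 h (a lower number here means a stronger inhibitor of growth, a higher number a weaker inhibitor of growth), and compound 2 `O=S(=O)(NCCCNCc1ccc(Cl)c(Cl)c1)c1cc(C(F)(F)F)cc(C(F)(F)F)c1` gives 2700 nM; the change from compound 1 to compound 2 reads a 1.2-fold higher number from compound 1 to compound 2 (0.07 log units; within the scatter). Compound 3 `COc1ccc(S(=O)(=O)NCCCCCCNCc2ccc(Br)cc2)cc1` gives 13000 nM in this assay, the highest of the three numbers, with compound 2 nearest and compound 1 furthest, both gaps beyond the scatter. Compound 4 `CC(C)c1ccc(S(=O)(=O)NCCCCCCNCc2ccc(Br)cc2)cc1` differs from compound 3 by isopropyl in place of methoxy on an aromatic carbon. Among the compounds with values here, no measured step touches this position; the only step in hand, from compound 1 to compound 2, alters the benzyl aryl and gives no guide to the sulfonyl aryl. An unchanged or modestly lower number is therefore expected for compound 4, about a 1.6-fold lower number from compound 3 to compound 4 (0.21 log units; within the scatter), with compound 4 estimated at 8000 nM within 3000 nM to 25000 nM.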

Compound 4, concentration for 50% growth inhibition: 5730 nM
For compound 4 the middle estimate is 1.4-fold (0.14 log units) above the measured one, within the range that was stated.
By their numbers in this assay, from the lowest: compounds 1 and 2 (each within the scatter of the next); then compound 4; then compound 3.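

In this assay, within the data shown here, this position is not silent: 4-isopropylphenyl in place of 4-methoxyphenyl gives a 2.3-fold lower number from compound 3 to compound 4 (0.36 log units; beyond the scatter) and is the first single-place step to lie beyond the scatter. The earlier step, a 1.2-fold higher number from compound 1 to compound 2 (0.07 log units; within the scatter), lay at a different place and stayed within the scatter. No measurement in hand bears on the origin of the new step.

The compounds shown leave open how a nitrile or a carboxylic acid would read at this position. They also leave open whether the same step would hold on a shorter chain.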